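The source may hold more compounds than are shown below. What is called first, only, known or untested is meant among the compounds shown, and "the series" means these compounds.

Measured in a functional assay on MCF7 cells (Homo sapiens) for antiproliferative activity, read by MTT assay, with a stated time of 72 h; a lower number here means a stronger inhibitor, a higher number a weaker inhibitor:
- Compound 1 `CCN1CCN(c2cc(C)c3cc(NC(=O)c4ccccc4)ccc3n2)CC1`: 14200 nM
- Compound 2 `Cc1cc(N2CCCC2)nc2ccc(NC(=O)c3ccc(Cl)c(Cl)c3)cc12`: 26300 nM
- Compound 3 `CCN(CC)c1cc(C)c2cc(NC(=O)c3ccc(Cl)c(Cl)c3)ccc2n1`: > 50000 nM (a limit)

Compound 1 at 14200 nM and compound 2 at 26300 nM lie within the scatter of each other. Going by the values given here, the reading for compound 3 is a limit, not a number, so compound 1 has only one numerical neighbour.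

Compound 4 `CCN1CCN(c2cc(C)c3cc(NC(=O)c4ccccc4Br)ccc3n2)CC1` follows from compound 1 by a single change: bromo in place of hydrogen on an aromatic carbon of a six-membered aromatic ring of carbon only, ortho to a large group (bromo in place of hydrogen on an aromatic carbon). Cut one bond further out, this reads phenyl to 2-bromophenyl.

Among the compounds with values here, the only measured single-place step is an at least 1.9-fold higher number from compound 2 to compound 3 (0.27 log units; that floor lies within the scatter). Within the data shown here, it involves diethylamino in place of pyrrolidin-1-yl on an aromatic carbon, a different place from the one that changes here, and it lies within the scatter. Among the measured compounds shown here, no measured step therefore shows what bromo does on this ring. With so little to go on, no step beyond the scatter is expected in this assay, and any upward move would run towards (the limit of > 50000 nM in this assay, at which 1 of the 3 values shown sits).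

The expected change is a 1.1-fold higher number from compound 1 to compound 4 (0.05 log units; within the scatter). For compound 4 the estimated value is 16000 nM, with an expected range of 6000 nM to 45000 nM.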

Compound 4, half-maximal inhibitory concentration: 27500 nM
Beside the measured number, compound 4's estimate is 1.7-fold (0.24 log units) below it, within the range that was stated.
By their numbers in this assay, from the lowest: compounds 1, 2 and 4 (each within the scatter of the next). At a limit, above all of these: compound 3.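

In this assay, bromo in place of hydrogen on an aromatic carbon, ortho to a large group, now has a measured step of its own: a 1.9-fold higher number from compound 1 to compound 4 (0.29 log units; within the scatter). The earlier compounds shown here held no step at this position; this one shows that phenyl to 2-bromophenyl, with the rest of compound 1 kept, gives no difference that stands clear of the scatter, and compound 4 at 27500 nM still reads as a number. Compound 3 alone stands at a limit: the limit of > 50000 nM in this assay, at which 1 of the 4 values shown sits.

One halogen at one place says little about the position as a whole, so a methoxy group, a primary amine or a carboxylic acid on the same carbon could still separate from compound 1 in either direction, and bromo elsewhere on this ring remains an open case. Also open, on these data alone, is whether the bromo step carries over to the dichlorophenyl amides of compound 2 and compound 3, and whether it holds with pyrrolidin-1-yl or diethylamino in place of the ethylpiperazine part of compound 4.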